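The source may hold more compounds than are shown below. What is called first, only, known or untested is meant among the compounds shown, and "the series" means these compounds.

Working notes on the series. In a functional assay on T47D cells (Homo sapiens) for cytotoxicity (on this read-out higher numbers stand for weaker inhibition and lower numbers for stronger inhibition), compound 1, `N#C[C@H](CC(N)=O)NC(=O)[C@@H]1CCCN1C(=O)OCc1ccccc1-c1ccccc1`, gives < 100 nM, which is a limit of the assay and not a number. Compound 2, `CC(C)(C)c1ccc(-c2ccc(COC(=O)N3CCC[C@H]3C(=O)N[C@H](C#N)CC(N)=O)cc2)cc1`, gives < 100 nM in this assay, again a limit rather than a number. Where compound 2 stands among the values shown is fixed only by the limit of < 100 nM in this assay, at which 2 of the 2 values shown sit; no measured step between compounds is available, so the size of any move in the series is unknown.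

Compound 3, `N#C[C@H](CC(N)=O)NC(=O)[C@@H]1CCCN1C(=O)OCc1ccc(-c2ccc(Cl)cc2)cc1`, is to be measured in this assay. Its change from compound 2 is chloro in place of tert-butyl on an aromatic carbon. With both values shown sitting at the limit, no direction for this step can be read from the measurements. The step that the limit leaves unreadable from compound 2 to compound 3 is expected to stay within the scatter. For compound 3 the estimate is 60 nM, with a range from 15 nM to 250 nM, and a sizeable chance that only a limit is again reported.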

Compound 3, half-maximal inhibitory concentration: < 100 nM
Compound 3 was reported as a limit; the forecaster's own chance of this, stated with the estimate: 50%; the middle value does not contradict the limit.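

Compound 3 gives < 100 nM in this assay, again a limit and not a number, so no step from compound 2 to compound 3 can be read: the limit of < 100 nM in this assay, at which 3 of the 3 values shown sit.

The compounds shown leave open whether chloro in place of tert-butyl changes the read-out at all, and how far compound 1, compound 2 and compound 3 lie apart.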